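The compounds below may be only part of what the source reports. "The series", "measured", "known", "first", "only" and "open" are said of these compounds alone.

Measured so far in an ADME assay on S9 fraction from liver (Homo sapiens) for metabolic stability, read by LC-MS, using NADPH, with a stated time of 90 min, tested at 5 uM; a higher number here means that more of the compound is left, a lower number that less of the compound is left:
compound 1 `O=C(NO)c1cc(F)c(Cn2nnc(-c3ccco3)n2)c(F)c1` with 94% remaining
compound 2 `Cn1c(Sc2c(F)cc(C(=O)NO)cc2F)nnc1-c1cccs1` with 83% remaining
compound 3 `Cn1c(Sc2c(F)cc(C(=O)NO)cc2F)nnc1-c1cccnn1` with 79% remaining

Compound 1 stands highest of these three numbers, and its gaps to compound 2 and to compound 3 both lie beyond the usual scatter. The piece now turns to compound 4 `Nc1ccc(-c2nnn(Cc3c(F)cc(C(=O)NO)cc3F)n2)cc1` and its relation to compound 1: 4-aminophenyl in place of furan-2-yl on an aromatic carbon (4-aminophenyl in place of furan-2-yl on an aromatic carbon of a five-membered aromatic ring with 4 nitrogen).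

Among the compounds with values here, only one measured step offers a comparison. It also swaps one aromatic ring for another on an aromatic carbon, though on a different core: a number 4 percentage points lower from compound 2 to compound 3 (within the scatter) (pyridazin-3-yl in place of thiophen-2-yl). Within the data shown here, no measured compound carries 4-aminophenyl, so this single step is weak guidance. It points to no change beyond the scatter in this assay for such a swap. A small fall is still the likelier direction, since compound 1 sits at the top and compound 2 reads lower (83% remaining). The step expected is a number 8 percentage points lower from compound 1 to compound 4 (within the scatter) and no more than the usual scatter. For compound 4 the estimate is 86% remaining, with an expected range from 68% to 98% in this assay.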

Compound 4, percent of the compound remaining: 74%
Compound 4: the middle estimate sits 12 percentage points above what was measured; the range from low to high includes it.
By their numbers in this assay, from the lowest: compounds 4, 3 and 2 (each within the scatter of the next); then compound 1.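

Within the data shown here, on the aromatic carbon of the five-membered aromatic ring with 4 nitrogen, putting 4-aminophenyl in place of furan-2-yl gives, in this assay, a number 20 percentage points lower from compound 1 to compound 4 (beyond the scatter), so the group at this position can move the percent of compound remaining beyond the scatter, which the only earlier step of this kind, a number 4 percentage points lower from compound 2 to compound 3 (within the scatter), on a different core, did not show. The entering group differs from the leaving one in its ring size, in having a ring of carbon only and in carrying a hydrogen-bond donor, and this single step cannot tell which of these differences goes with the lower number. Nothing measured here bears on the reason for this step.

The compounds shown leave open whether a plain phenyl group, without the amine, would read closer to compound 1 or to compound 4, and whether a hydroxyl group or a methoxy group in place of the amine would give the same result. They also leave open whether 4-aminophenyl would have a similar effect on the core of compound 2.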